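Swapping the Amide Ring in a Kinase-Type Inhibitor Series

The source may report more compounds than this note shows. Statements on the series, on what has been measured and on what is new or still open speak of the compounds shown alone.

Three compounds share one core and differ only at the edges. In a functional assay on A549 cells (Homo sapiens) for antiproliferative activity, read by MTT assay, with a stated time of 72 h (on this read-out higher numbers stand for weaker inhibition and lower numbers for stronger inhibition), compound 1 `COc1cc(F)c(NC(=O)c2ccncc2)cc1Nc1nccc(-c2cn(C)c3ccccc23)n1` gives 4200 nM, compound 2 `COc1cc(F)c(NC(=O)c2ccncc2OC)cc1Nc1nccc(-c2cn(C)c3ccccc23)n1` gives 3430 nM, and compound 3 `COc1cc(N(C)CCN(C)C)c(NC(=O)c2ccncc2OC)cc1Nc1nccc(-c2cn(C)c3ccccc23)n1` gives 2690 nM; all three numbers lie within the scatter of one another, so compound 3 stands level with the rest. The steps were a 1.2-fold lower number from compound 1 to compound 2 (0.09 log units; within the scatter) and a 1.3-fold lower number from compound 2 to compound 3 (0.11 log units; within the scatter). Compound 4 `COc1cc(N(C)CCN(C)C)c(NC(=O)c2ncccn2)cc1Nc1nccc(-c2cn(C)c3ccccc23)n1` carries a different change: pyrimidin-2-yl in place of 3-methoxypyridin-4-yl on a carbonyl carbon. Among the compounds with values here, no measured step swaps this ring, and the only step touching it, from compound 1 to compound 2, stayed within scatter, so no step beyond scatter is expected in this assay, an estimated 1.0-fold higher number from compound 3 to compound 4 (0.02 log units; within the scatter). Compound 4 is thus expected at 2800 nM, within 900 nM to 9000 nM.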

Compound 4, half-maximal inhibitory concentration: 2490 nM
Estimate against measurement, compound 4: 1.1-fold (0.05 log units) above, within the range that was stated.
By their numbers in this assay, from the lowest: compounds 4, 3, 2 and 1 (each within the scatter of the next).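

At this position a whole ring can be exchanged, not just given a methoxy: in this assay pyrimidin-2-yl in place of 3-methoxypyridin-4-yl on the carbonyl carbon gives a 1.1-fold lower number from compound 3 to compound 4 (0.03 log units; within the scatter) with the chain of compound 3 kept in place. A six-membered aromatic ring with 2 hetero atoms thus reads level with one carrying 1 hetero atom. Nothing available explains this result. Still open, on these data alone, is whether a plain phenyl ring, or a saturated amine such as piperidine or morpholine, on that carbonyl carbon would also read level.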